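Swapping the ester group in a selenocyanate carbamate series

The compounds below may be only part of what the source reports. "The series", "measured", "known", "first", "only" and "open" are said of these compounds alone.

Three carbamates that share a selenocyanate-bearing core have been tested in a functional assay on HT-29 cells (Homo sapiens) for cytotoxicity, read by MTT assay, with a stated time of 72 h; on this read-out lower numbers stand for stronger inhibition of growth and higher numbers for weaker inhibition of growth. Compound 1, with a benzyl ester `N#C[Se]c1ccc(NC(=O)OCc2ccccc2)cc1`, gives 41200 nM. Compound 2, the ethyl ester `CCOC(=O)Nc1ccc([Se]C#N)cc1`, gives 38000 nM. Compound 3, the phenyl ester `N#C[Se]c1ccc(NC(=O)Oc2ccccc2)cc1`, gives 41700 nM. All three numbers lie within the usual scatter of one another, so no one of them can be called stronger or weaker than the others on this evidence.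

Compound 4 `CC(C)COC(=O)Nc1ccc([Se]C#N)cc1` differs from compound 3 in one place: isobutyl in place of phenyl on an oxygen next to a carbonyl group. Among the compounds with values here, the closest precedent is the step of a 1.1-fold higher number from compound 2 to compound 3 (0.04 log units; within the scatter), in which the group on the same oxygen was also exchanged, and the step of a 1.1-fold lower number from compound 1 to compound 2 (0.04 log units; within the scatter), in which the size of that group changed again without moving the number beyond the scatter. Both steps suggest that the identity of the group on the oxygen next to the carbonyl group has little bearing on this assay across the cases seen so far.

Compound 4 is therefore expected to sit close to compound 3, with an expected step of a 1.0-fold lower number from compound 3 to compound 4 (0.02 log units; within the scatter). The estimate for compound 4 in this assay is 40000 nM, with a likely range from 20000 nM to 80000 nM.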

Compound 4, concentration for total growth inhibition: 31300 nM
Estimate against measurement, compound 4: 1.3-fold (0.11 log units) above; measured number inside the range.
By their numbers in this assay, from the lowest: compounds 4, 2, 1 and 3 (each within the scatter of the next).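

Isobutyl brings a branched chain to this place, on an oxygen next to a carbonyl group, and in this assay all three steps to it stay within the scatter: a 1.3-fold lower number from compound 3 to compound 4 (0.12 log units; within the scatter), a 1.2-fold lower number from compound 2 to compound 4 (0.08 log units; within the scatter) and a 1.3-fold lower number from compound 1 to compound 4 (0.12 log units; within the scatter). Compound 3 carries phenyl with its six-membered aromatic ring, while compound 4 carries isobutyl with no ring, yet the two numbers cannot be told apart, so in these four compounds neither the ring nor the branching separates one carbamate from another. No separate evidence is available on what lies behind this flat result.

All four groups at this place consist of carbon and hydrogen alone, so the effect of a chain ending in an amine or a carboxylic acid, or of a much longer chain, remains an open question. The selenocyanate group and the rest of the shared core are also the same throughout, which leaves open how the numbers would respond if the selenocyanate gave way to a plain nitrile.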